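The source may report more compounds than this note shows. Statements on the series, on what has been measured and on what is new or still open speak of the compounds shown alone.

Values measured in a physicochemical assay for lipophilicity, using the shake flask method; a lower number here means a more polar compound, a higher number a more lipophilic compound:
- compound 1 `Cc1c(/C=C/C(=O)O)cnc2ccc(O[C@@H](C)c3c(Cl)ccc(F)c3Cl)cc12` gives 3
- compound 2 `C[C@H](Oc1ccc2ncc(/C=C/C(=O)O)c(C(F)F)c2c1)c1c(Cl)ccc(F)c1Cl` gives 3.1
- compound 3 `C[C@H](Oc1ccc2ncc(/C=C/C(=O)O)c(N(C)C)c2c1)c1c(Cl)ccc(F)c1Cl` gives 3.6

Compound 3 stands highest of the three in this assay, with both of the others beyond the scatter from it. The next compound in the series is compound 4 `C[C@H](Oc1ccc2ncc(/C=C/C(=O)O)c(O)c2c1)c1c(Cl)ccc(F)c1Cl`, which has not yet been measured. It differs from compound 3 as follows: hydroxy in place of dimethylamino on an aromatic carbon, opposite the ring nitrogen.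

Going by the values given here, no measured step brings in hydroxy, so the evidence is indirect. The two measured steps that bring in dimethylamino are a number 0.60 log units higher from compound 1 to compound 3 (beyond the scatter) and a number 0.50 log units higher from compound 2 to compound 3 (beyond the scatter). The step between the other two groups is a number 0.10 log units higher from compound 1 to compound 2 (within the scatter). Removing dimethylamino is therefore expected to lower the number, by somewhat more than those two modest steps. The expected step is a number 1.20 log units lower from compound 3 to compound 4 (beyond the scatter). For compound 4 the estimated value is 2.4, with an expected range from 1.7 to 3.1.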

Compound 4, distribution coefficient: 1.9
For compound 4 the middle estimate is 0.50 log units above the measured one; the range from low to high includes it.
By their numbers in this assay, from the lowest: compound 4; then compounds 1 and 2 (each within the scatter of the next); then compound 3.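

In this assay, going by these compounds alone, the position opposite the ring nitrogen turns out to tolerate far wider swings than the earlier compounds showed, where the exchanges among methyl, difluoromethyl and dimethylamino gave modest steps or none beyond the scatter. Hydroxy in place of dimethylamino gives a number 1.70 log units lower from compound 3 to compound 4 (beyond the scatter), hydroxy in place of difluoromethyl gives a number 1.20 log units lower from compound 2 to compound 4 (beyond the scatter) and hydroxy in place of methyl gives a number 1.10 log units lower from compound 1 to compound 4 (beyond the scatter), so all three steps are large and compound 4 stands lowest of the four. Nothing measured here accounts for the size of these steps.

As far as these compounds go, it remains open whether methoxy, which keeps the oxygen but carries no hydrogen-bond donor, would read close to compound 4 or to the others. Methylamino at the same carbon poses the same question for the nitrogen series.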